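This account rests on a few compounds, and the source may have more. Where it says the series, first, only, none or still open, it means among the compounds named here.

Measured in a functional assay on HL-60 cells (Homo sapiens) for inhibition, read by CCK-8 assay, with a stated time of 48 h, tested at 20 uM; a lower number here means less inhibition of growth, a higher number more inhibition of growth at the concentration tested:
- compound 1 `N#C/C(=C\c1ccccc1OS(=O)(=O)c1ccc(Cl)cc1)C(=O)Nc1nnc(Cc2cccc3ccccc23)s1`: 15%
- compound 2 `COc1ccc(S(=O)(=O)Oc2ccccc2/C=C(\C#N)C(=O)Nc2nnc(Cc3ccccc3)s2)cc1`: 100%
- compound 3 `N#C/C(=C\c1ccccc1OS(=O)(=O)c1ccccc1[N+](=O)[O-])C(=O)Nc1nnc(Cc2ccccc2)s1`: 12%

Compound 3, at 12%, sits within the scatter of compound 1 and far from compound 2. The next compound is compound 4 `N#C/C(=C\c1ccccc1OS(=O)(=O)c1ccc(Cl)cc1)C(=O)Nc1nnc(Cc2ccccc2)s1`, which carries 4-chlorophenyl in place of 2-nitrophenyl on a sulfonyl sulfur.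

For the measured compounds named here, one measured step bears directly on this place: a number 88 percentage points lower from compound 2 to compound 3 (beyond the scatter). It shows that exchanging the aryl group on the sulfonyl sulfur can move this assay across nearly the whole scale. That step involves a different incoming group, however. Going by the values given here, compound 1 has the same 4-chlorophenyl and gives 15%, but it differs from compound 4 elsewhere in the structure, and no measured step isolates that difference. Some rise is therefore expected, though its size is poorly constrained.

The expected change is a number 23 percentage points higher from compound 3 to compound 4 (beyond the scatter), and this estimate is loose. Compound 4 is estimated at 35%, with an expected range of 8% to 90%.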

Compound 4, percent growth inhibition at one concentration: 26%
The estimate for compound 4 lay 9 percentage points above the measured number; measured number inside the range.
By their numbers in this assay, from the lowest: compounds 3 and 1 (each within the scatter of the next); then compound 4; then compound 2.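

In this assay the step of a number 14 percentage points higher from compound 3 to compound 4 (beyond the scatter) separates 4-chlorophenyl from 2-nitrophenyl on the sulfonyl sulfur by much less than the earlier exchange of aryl groups at this place, while the step of a number 74 percentage points lower from compound 2 to compound 4 (beyond the scatter) ties a large change to chloro in place of methoxy on an aromatic carbon. For the compounds shown here, at the other end of the molecule the step of a number 11 percentage points higher from compound 1 to compound 4 (beyond the scatter) gives the first single-place reading for phenyl in place of naphthalen-1-yl on a saturated chain carbon bound to an aromatic carbon, and that change is modest. Nothing available accounts for the size of these steps.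

Still open, from the compounds shown here alone, is whether the high reading depends on methoxy itself or would also appear with an amino or hydroxy group on that aromatic carbon. Also open, going by these compounds, is whether methoxy would keep that reading with naphthalen-1-yl on the chain carbon.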